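The source may report more compounds than this note shows. Statements on the series, on what has been measured and on what is new or still open speak of the compounds shown alone.

Measured compounds:
compound 1 `CCOC(=O)c1sc(-c2cccc(NC(=O)c3ccc(F)cc3)c2)nc1Nc1ccc(N2CCN(C)CC2)cc1` – 16.8%
compound 2 `CCOC(=O)c1sc(-c2cccc(NC(=O)c3ccccc3)c2)nc1Nc1ccc(N2CCN(C)CC2)cc1` – 42%
compound 3 `CCOC(=O)c1sc(-c2cccc(NC(=O)c3ccc(Cl)cc3)c2)nc1Nc1ccc(N2CCN(C)CC2)cc1` – 24.3%

In a functional assay on Raji cells (Homo sapiens) for antiproliferative activity, read by CCK-8 assay, with a stated time of 72 h, tested at 40 uM (on this read-out higher numbers stand for more inhibition at the one concentration tested (going by the name of the read-out) and lower numbers for less inhibition), compound 2 stands highest of the three: compound 3 is nearest, a number 17.7 percentage points lower from compound 2 to compound 3 (beyond the scatter), and compound 1 is furthest, a number 25.2 percentage points higher from compound 1 to compound 2 (beyond the scatter). Compound 4 `CCOC(=O)c1sc(-c2cccc(NC(=O)c3ccc(C(F)(F)F)cn3)c2)nc1Nc1ccc(N2CCN(C)CC2)cc1` differs from compound 2 in one place: 5-(trifluoromethyl)pyridin-2-yl in place of phenyl on a carbonyl carbon. Among the measured compounds shown here, the measured steps touch only a single substituent on that ring, never the ring itself: a number 25.2 percentage points higher from compound 1 to compound 2 (beyond the scatter), a number 17.7 percentage points lower from compound 2 to compound 3 (beyond the scatter) and a number 7.5 percentage points higher from compound 1 to compound 3 (within the scatter). For the measured compounds named here, both substituted variants, compound 1 and compound 3, sit below the unsubstituted compound 2, so compound 4, which carries a trifluoromethyl group and a ring nitrogen, is expected to drop by a modest step, a number 17 percentage points lower from compound 2 to compound 4 (beyond the scatter), with the ring nitrogen having no precedent here. Compound 4 is estimated at 25%, within 8% to 45%.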

Compound 4, a percentage reported as inhibition, at one concentration (the size of the read-out at that concentration, not a potency): 20.8%
Estimate against measurement, compound 4: 4.2 percentage points above; the range from low to high includes it.
By their numbers in this assay, from the lowest: compounds 1, 4 and 3 (each within the scatter of the next); then compound 2.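

In this assay, exchanging the phenyl ring itself for 5-(trifluoromethyl)pyridin-2-yl, rather than only adding a halogen to it, also lowers inhibition (a number 21.2 percentage points lower from compound 2 to compound 4 (beyond the scatter)). Among the compounds shown here, the result cannot be told apart from the 4-chlorophenyl (a number 3.5 percentage points lower from compound 3 to compound 4 (within the scatter)) or the 4-fluorophenyl (a number 4 percentage points higher from compound 1 to compound 4 (within the scatter)), so the unsubstituted phenyl of compound 2 remains the only group here that stands apart. Nothing measured here explains the drop.

Going by these compounds, the trifluoromethyl group and the ring nitrogen enter together, so their separate contributions stay unknown; a plain pyridin-2-yl would separate them. On these data alone, how an amine or a carboxylic acid on this ring would read also remains open.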